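Methyl in Place of Hydrogen on the Ring Nitrogen

A few compounds are considered here, and "the series" means these few. Any claim that something is new, unique, unknown or untested is made for them only; others in the source may bear on it.

Measured compounds:
- Compound 1 `O=C(Nc1ccc(Oc2ccnc3[nH]ccc23)cc1)c1cc2cccnc2n(-c2ccc(F)cc2)c1=O`: in a functional assay on U-87MG ATCC cells for antiproliferative activity against U-87 MG (Homo sapiens), read by MTT assay, with a stated time of 72 h (on this read-out higher numbers stand for weaker inhibition and lower numbers for stronger inhibition), compound 1 gives 1360 nM.
- Compound 2 `O=C(Nc1ccc(Oc2ccnc3[nH]ccc23)cc1)c1cc2cccnc2n(-c2ccc(Br)cc2)c1=O`: in this assay the entry for compound 2 reads "not determined" (no result reported), so no number was obtained.
- Compound 3 `O=C(Nc1ccc(Oc2ccnc3[nH]ccc23)cc1)c1cc2cccnc2n(-c2ccc(Br)cc2F)c1=O`: in this assay the entry for compound 3 reads "not determined" (no result reported), so no number was obtained.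

Among the measured compounds shown here, compound 1 therefore stands alone: it is the only compound of the three with a measured value in this assay, and compounds 2 and 3 give no number to set beside it. For the measured compounds named here, with a single value there is no step between measured compounds to learn from, so any expectation for a new compound rests on the structure of compound 1 and the size of the change made to it.

Compound 4 `Cn1ccc2c(Oc3ccc(NC(=O)c4cc5cccnc5n(-c5ccc(F)cc5)c4=O)cc3)ccnc21` is compound 1 with one small alteration: methyl in place of hydrogen on an aromatic nitrogen. The rest of the molecule, the amide, the ether link and the shared core, is left untouched.

Going by the values given here, since no comparable step is available, the expectation is cautious. A change of one heavy atom on the fused two-ring system is estimated to shift the value only modestly, most likely toward weaker inhibition, and not clearly beyond the usual scatter of repeated measurements; the step from compound 1 to compound 4 is expected to be a 1.6-fold higher number from compound 1 to compound 4 (0.21 log units; within the scatter). Compound 4 is accordingly estimated at 2200 nM in this assay, with a plausible range from 700 nM to 7000 nM.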

Compound 4, half-maximal inhibitory concentration: 2120 nM
Compound 4: the middle estimate sits 1.0-fold (0.02 log units) above what was measured; low and high end bracket the measured number.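

All three earlier compounds carry hydrogen on the ring nitrogen of the shared core, so they could say nothing about a change at this position; the first view comes from this assay, where methyl in place of hydrogen on this aromatic nitrogen gives a 1.6-fold higher number from compound 1 to compound 4 (0.19 log units; within the scatter) in the read-out. In this single pair, the hydrogen on that nitrogen can therefore be replaced by methyl without a difference that stands clear of ordinary repeat-to-repeat variation, and the position can carry at least this one added carbon while the rest of the molecule stays the same. Nothing among the data shown offers an explanation for this outcome.

Going by these compounds, one small group on one compound cannot show how much room this position allows, so it remains open whether an ethyl group, a longer chain or a chain ending in an amine on the same nitrogen would leave the read-out equally undisturbed. On these data alone, it is also open whether methyl would behave in the same way in the bromine-bearing compound 2 and compound 3, for which no number is available to serve as a starting point.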